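The compounds below may be only part of what the source reports. "The series", "measured", "known", "first", "only" and "open" are said of these compounds alone.

In a functional assay on OVCAR-8 cells (Homo sapiens) for inhibition, read by sulforhodamine B assay, with a stated time of 72 h (a higher number here means a weaker inhibitor, a lower number a stronger inhibitor), compound 2 (`CCNC1=C(C)C(=O)C=C(C(C)C)C1=O`) gives 16000 nM and compound 1 (`CNC1=C(C)C(=O)C=C(C(C)C)C1=O`) gives 12900 nM in the same test, so the two stand level. Compound 3 (`CC1=C(N)C(=O)C(C(C)C)=CC1=O`) has not yet been measured. It carries hydrogen in place of ethyl on an amine nitrogen, which turns ethylamino into amino. Among the compounds with values here, only one measured step bears on this change, and it also alters the chain on that nitrogen: the step is a 1.2-fold higher number from compound 1 to compound 2 (0.09 log units; within the scatter) and it is a small guide, since no measured compound lacks a chain there. On the strength of that step, no change beyond the scatter is expected in this assay, though the range must stay wide. The estimated change is a 1.2-fold lower number from compound 2 to compound 3 (0.09 log units; within the scatter) at its centre. For compound 3 the estimate is 13000 nM with an expected range of 5500 nM to 30000 nM in this test.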

Compound 3, half-maximal inhibitory concentration: 35100 nM
Estimate against measurement, compound 3: 2.7-fold (0.43 log units) below; measured number outside the range, above it.
By their numbers in this assay, from the lowest: compounds 1 and 2 (each within the scatter of the next); then compound 3.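

In this assay, within the data shown here, the change from ethylamino to amino is a first step at this position that clearly moves the number: a 2.2-fold higher number from compound 2 to compound 3 (0.34 log units; beyond the scatter) when the ethyl on the amine nitrogen gives way to hydrogen, and a 2.7-fold higher number from compound 1 to compound 3 (0.43 log units; beyond the scatter) when the methyl does. Methyl and ethyl had stood level, so among these three compounds, having a chain on this nitrogen matters more than which of the two chains it is, and compound 3, with the bare amino group, is the weakest inhibitor. Nothing given here explains this difference.

As far as these compounds go, it remains open whether a longer chain such as propyl or butyl on this nitrogen would keep the number level with methyl and ethyl or shift it. A ring such as cyclopropyl or an acetyl group in the same place is also untested among the compounds shown.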